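Swapping an oxetane for a pyrazole on the amide nitrogen

The source may report more compounds than this note shows. Statements on the series, on what has been measured and on what is new or still open speak of the compounds shown alone.

Of the compounds shown here, three have been tested in an assay on HEK293 cells for agonist activity at transient receptor potential cation channel subfamily M member 8 (Homo sapiens), read by fluorescence and calcium flux, with a stated time of 15 min; on this read-out higher numbers stand for an effect only at larger amounts of compound and lower numbers for an effect already at smaller amounts. Compound 1, with structure `Cc1ccc(OCC(=O)N(Cc2cccs2)C2COC2)cc1`, gives 23000 nM, the highest of the three numbers. Compound 2, with structure `CCN(Cc1ccco1)C(=O)COc1ccc(C)cc1`, gives 489 nM. Compound 3, with structure `O=C(COc1ccc2c(c1)CCC2)N(Cc1cccs1)c1ccn[nH]1`, gives 0.001 nM, by far the lowest number of the set and far beyond the usual scatter away from compound 1.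

Compound 4, with structure `Cc1ccc(OCC(=O)N(Cc2cccs2)c2ccn[nH]2)cc1`, has not yet been measured. It differs from compound 1 in one place: 1H-pyrazol-5-yl in place of oxetan-3-yl on an amide-type nitrogen. The group that enters is the very group that compound 3 carries on its amide nitrogen, and compound 3 is the compound with the lowest number measured. Within the data shown here, no directly comparable step is available, so the size is uncertain, but a large move downward is expected. For compound 4 the estimate in this assay is 20 nM, with a plausible range from 0.5 nM to 800 nM. This expected result corresponds to a step of a 1200-fold lower number from compound 1 to compound 4 (3.06 log units; beyond the scatter).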

Compound 4, half-maximal effective concentration: 0.2 nM
Estimate against measurement, compound 4: 100-fold (2.00 log units) above; measured number outside the range, below it.
By their numbers in this assay, from the lowest: compound 3; then compound 4; then compound 2; then compound 1.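

With the rest of the molecule unchanged, placing 1H-pyrazol-5-yl instead of oxetan-3-yl on the amide-type nitrogen gives, in this assay, a 120000-fold lower number from compound 1 to compound 4 (5.06 log units; beyond the scatter). Among these compounds, no earlier pair of compounds differed in only one place, so this is the first evidence that this position alone can shift the number by far more than the usual scatter. The change replaces a four-membered non-aromatic ring having no hydrogen-bond donor with a five-membered aromatic ring having one, but nothing measured here shows which of these differences matters.

From the compounds shown here alone, it remains open whether any aromatic ring would do at this position, which a phenyl ring there would test. Also unsettled is whether the hydrogen-bond donor is needed, which a methyl group on the pyrazole nitrogen would test.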